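The source may report more compounds than this note shows. Statements on the series, on what has been measured and on what is new or still open speak of the compounds shown alone.

Of the compounds shown here, three built on a shared core have been measured in an assay for inhibition of Amine oxidase [flavin-containing] B (Rattus norvegicus); a higher number here means a weaker inhibitor, a lower number a stronger inhibitor. Compound 1, `NC(=O)[C@@H]1CCCN1c1cc(=O)oc2cc(OCc3ccccc3)ccc12`, gives 16100 nM in this assay, the highest number of the three and so the weakest inhibitor among them. Compound 2, `NC(=O)[C@H](CO)Nc1cc(=O)oc2cc(OCc3cccc(Cl)c3)ccc12`, gives 2400 nM, a lower number than compound 1 by a margin beyond the scatter. Compound 3, `NC(=O)Cc1cc(=O)oc2cc(OCc3cccc(O)c3)ccc12`, gives 1000 nM, the lowest number of the three, again beyond the scatter from compound 1.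

Compound 4, `CNCc1cc(=O)oc2cc(OCc3ccccc3)ccc12`, has not been measured. It differs from compound 1 in one place: (methylamino)methyl in place of 2-carbamoylpyrrolidin-1-yl on an aromatic carbon. Among the compounds with values here, no measured pair differs in just one place, so no measured step speaks directly to this change. Within the data shown here, what can be said is that compound 2 and compound 3 both carry smaller groups than the one compound 1 carries, and both give lower numbers than compound 1.

Compound 4 is therefore expected to give about 3000 nM, within a range from 500 nM to 20000 nM. That estimate amounts to an expected step of a 5.4-fold lower number from compound 1 to compound 4 (0.73 log units; beyond the scatter), toward a stronger inhibitor and beyond the scatter, though the ground for it is thin.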

Compound 4, half-maximal inhibitory concentration: 28 nM
The estimate for compound 4 lay 110-fold (2.03 log units) above the measured number, and the stated range ends above it.
By their numbers in this assay, from the lowest: compound 4; then compound 3; then compound 2; then compound 1.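

Within the data shown here, replacing 2-carbamoylpyrrolidin-1-yl with (methylamino)methyl on this aromatic carbon, opposite the ring oxygen, gives in this assay a 580-fold lower number from compound 1 to compound 4 (2.76 log units; beyond the scatter) and is the first change here that can be read on its own. With the rest of compound 1 left as it is, the group at this one position can by itself shift the number by a large margin toward a stronger inhibitor. The step changes several things at once, though: the ring, the stereocentre, the carbonyl of the amide and much of the heavy-atom count all leave together, so this single pair cannot show which of them matters.

Still open, on these data alone, is how the number would respond to a simple aminomethyl group, a dimethylaminomethyl group or a longer chain such as (ethylamino)methyl at this position. Nothing measured here accounts for the size of the step.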